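This account rests on a few compounds, and the source may have more. Where it says the series, first, only, none or still open, it means among the compounds named here.

Of the compounds shown here, three have been measured in a functional assay on UACC-257 cells (Homo sapiens) for inhibition, read by sulforhodamine B assay, with a stated time of 48 h; on this read-out higher numbers stand for weaker inhibition of growth and lower numbers for stronger inhibition of growth: compound 1 `Nc1cc(N)c2nc(-c3ccccc3)c(Oc3ccc(Cl)c(Cl)c3)nc2c1` gives 28200 nM; compound 2 `CCOC(=O)[C@H](CCC(=O)O)NC(=O)c1ccc(CNc2nc3cc(N)cc(N)c3nc2-c2ccccc2)cc1` gives 19500 nM; compound 3 `COc1cc(CNc2nc3cc(N)cc(N)c3nc2-c2ccccc2)cc(OC)c1OC` gives 3470 nM.

Compound 1 has the highest number of the three. Compound 2 sits within the usual scatter of it, while compound 3 lies beyond the scatter with a clearly lower number. Compound 4 `Nc1cc(N)c2nc(-c3ccccc3)c(NCc3ccc(F)cc3)nc2c1` has not yet been measured; it differs from compound 1 by (4-fluorobenzyl)amino in place of 3,4-dichlorophenoxy on an aromatic carbon. Going by the values given here, no measured pair shows this change on its own. Compound 3 also carries a benzylamino group on the shared core and gives 3470 nM, so a downward step beyond the scatter is expected. The step of a 3.5-fold lower number from compound 1 to compound 4 (0.55 log units; beyond the scatter) is the estimated size of that drop. Compound 4 is expected to give 8000 nM, within 2500 nM to 25000 nM.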

Compound 4, concentration for 50% growth inhibition: 2040 nM
For compound 4 the middle estimate is 3.9-fold (0.59 log units) above the measured one; the measured number lies below the stated range.
By their numbers in this assay, from the lowest: compounds 4 and 3 (each within the scatter of the next); then compounds 2 and 1 (each within the scatter of the next).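

In this assay, going by these compounds alone, the change on this aromatic carbon, next to the ring nitrogen, gives a 14-fold lower number from compound 1 to compound 4 (1.14 log units; beyond the scatter) and is the first step read at a single place. The entering (4-fluorobenzyl)amino carries a hydrogen-bond donor and the leaving 3,4-dichlorophenoxy carries none, but no measurement given here links the step to this or any other difference. Still open, from the compounds shown here alone, is whether the step follows the nitrogen link or the extra carbon, which a benzyloxy or a phenylamino group at this position would separate.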